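This account rests on a few compounds, and the source may have more. Where it says the series, first, only, none or still open, it means among the compounds named here.

Measured compounds in a functional assay on MT4 cells (Homo sapiens) for antiproliferative activity, read by MTT assay, with a stated time of 96 h; a lower number here means a stronger inhibitor, a higher number a weaker inhibitor:
Compound 1, `CN(C)c1ccc(N2C(=O)NC3(CSC4=C3C(=O)c3ncccc3C4=O)C2=O)cc1`, gives 15 nM.
Compound 2, `O=C1NNC(=O)C2(CSC3=C2C(=O)c2ncccc2C3=O)N1`, gives 550 nM; 500 nM; 550 nM (3 entries), drawn from the several entries of compound 2 in this assay, 550 nM; 500 nM; 550 nM (3 entries).
Compound 3, `O=C1NN(c2ccccc2)C(=O)C2(CSC3=C2C(=O)c2ncccc2C3=O)N1`, gives 150 nM.

Among the compounds with a single number in this assay, compound 1 gives the lowest one. Its nearest neighbour is compound 3, whose number is higher by a margin beyond the usual scatter, so compound 1 stands as the stronger inhibitor of the two. Compound 2 is known only through several entries, and all of them lie well above the number of compound 1.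

Compound 4, `O=C1C2=C(C(=O)c3ncccc31)C1(CS2)NC(=O)N(c2ccncc2)C1=O`, is not yet measured in this assay. It differs from compound 1 in one place: pyridin-4-yl in place of 4-(dimethylamino)phenyl on an amide-type nitrogen in a ring. For the measured compounds named here, no measured pair in this set carries this change, so its size can only be guessed. The account expects a moderate rise in the number for compound 4, that is a weaker inhibitor than compound 1, but not a return to the level of compound 2. The expected step is a 5.3-fold higher number from compound 1 to compound 4 (0.73 log units; beyond the scatter). Compound 4 is therefore estimated at 80 nM, with a range from 25 nM to 300 nM.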

Compound 4, half-maximal inhibitory concentration: 3 nM
The estimate for compound 4 lay 27-fold (1.43 log units) above the measured number, and the stated range ends above it.
By their numbers in this assay, from the lowest: compound 4; then compound 1; then compound 3.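

In this assay, for the compounds shown here, pyridin-4-yl in place of 4-(dimethylamino)phenyl on the amide-type nitrogen gives a 5.0-fold lower number from compound 1 to compound 4 (0.70 log units; beyond the scatter), the first measured change at this position in the set. The step shows that the number responds to the group held on this nitrogen, and that the 4-(dimethylamino)phenyl group is not required for a low number on this core, since the entering group has fewer heavy atoms and still gives a stronger inhibitor. Nothing measured here accounts for the size or the direction of this step.

This single pair cannot separate the ring nitrogen of the pyridine from the loss of the dimethylamino group. As far as these compounds go, the same position carrying an unsubstituted phenyl or a pyridin-3-yl group would speak to that, and how far the trend extends remains open.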